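The source may report more compounds than this note shows. Statements on the series, on what has been measured and on what is new or still open speak of the compounds shown alone.

Measured so far:
compound 1 `CCC(C)(C)Cc1c[nH]c(CCc2ccc(-c3cccnc3)cc2)n1` — 131 nM
compound 2 `O=C(O)c1cc(F)c(F)cc1-c1ccc(CCc2nc(CC3CCCCC3)c[nH]2)cc1` — 63 nM

Two compounds share a core and were measured in a functional assay on HEK293 cells for agonist activity at Bombesin receptor subtype-3 (Homo sapiens), read by luminescence and calcium flux, with a stated time of 10 min; a higher number here means that more compound is needed for the effect, a lower number that less compound is needed. Compound 1 gives 131 nM, the higher of the two numbers. Compound 2 gives 63 nM, a lower number, and the gap between the two lies beyond the usual scatter. Going by the values given here, no pair of compounds differing in a single place has been measured, so no step size is known from the data.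

Compound 3 `CCC(C)(C)Cc1c[nH]c(CCc2ccc(-c3ccc(F)cn3)cc2)n1` is not yet measured. It differs from compound 1 in one place: 5-fluoropyridin-2-yl in place of pyridin-3-yl on an aromatic carbon. The entering group carries one fluorine and one more heavy atom than the leaving group, with the same count of hydrogen-bond donors and acceptors and no net charge.

Among the compounds with values here, with no measured step to rest on, a change of modest size in either direction is expected, likely not beyond the scatter. Compound 3 is estimated at 120 nM in this assay, within 45 nM to 320 nM, which means an expected step of a 1.1-fold lower number from compound 1 to compound 3 (0.04 log units; within the scatter).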

Compound 3, half-maximal effective concentration: 66 nM
Beside the measured number, compound 3's estimate is 1.8-fold (0.26 log units) above it; measured number inside the range.
By their numbers in this assay, from the lowest: compounds 2, 3 and 1 (each within the scatter of the next, the first and the last beyond it).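

In this assay, going by these compounds alone, the exchange of pyridin-3-yl for 5-fluoropyridin-2-yl on an aromatic carbon, para to a large group, gives the first single-place step: a 2.0-fold lower number from compound 1 to compound 3 (0.30 log units; within the scatter). The shared core therefore holds this larger ring group at this place without a step beyond the scatter, which the two earlier compounds, differing in more than one place, could not show. No accompanying measurement bears on this step, and nothing can be said about what lies behind it.

The step changes both the fluorine and the ring's point of attachment, so the compounds shown leave open what each contributes alone; a plain pyridin-2-yl would separate the two. Also open, on these data alone, is how this place responds to other ring substituents, such as a 5-chloro or a 5-methoxy group.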